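The source may report more compounds than this note shows. Statements on the series, on what has been measured and on what is new or still open speak of the compounds shown alone.

In an ADME assay on K562 cells (Homo sapiens) for antiproliferative activity (on this read-out higher numbers stand for weaker inhibition and lower numbers for stronger inhibition), compound 1 `COc1ccc2nccc(CC[C@H]3CC[C@H](NCc4ccc(Cl)c(Cl)c4)CC3)c2c1` is recorded as "not determined" (no result reported), so it offers no number for comparison. Compound 2 `COc1ccc2nccc(CC[C@H]3OC[C@H](NCc4cc5c(cn4)OCCO5)CO3)c2c1` gives 40000 nM and compound 3 `COc1ccc2nccc(CC[C@H]3OC[C@H](NCc4ccc(Cl)c(Cl)c4)CO3)c2c1` gives 20000 nM. Going by the values given here, compound 3 therefore stands within the scatter of compound 2, the only other number available. Compound 4 `COc1ccc2nccc(CC[C@H]3OC[C@H](NCc4ccc5c(n4)NC(=O)CO5)CO3)c2c1` keeps the core of compound 3 and differs only on a saturated chain carbon bound to an amine nitrogen: a group of 11 heavy atoms (7 carbon, 2 nitrogen, 2 oxygen; one six-membered non-aromatic ring with 2 hetero atoms, one six-membered aromatic ring with 1 hetero atom) in place of a group of 8 heavy atoms (6 carbon, 2 chlorine; one six-membered aromatic ring of carbon only), on a saturated chain carbon bound to an amine nitrogen. Among the compounds with values here, the 3,4-dichlorophenyl group leaves, and the entering group, like the one in compound 2, has one six-membered non-aromatic ring with 2 hetero atoms and one six-membered aromatic ring with 1 hetero atom. Within the data shown here, the only measured step that bears on this change is a 2.0-fold lower number from compound 2 to compound 3 (0.30 log units; within the scatter). It is a single small step, so no change beyond the scatter is expected in this assay. The expected step is a 1.5-fold higher number from compound 3 to compound 4 (0.18 log units; within the scatter). The estimate for compound 4 is 30000 nM, with an expected range from 12000 nM to 75000 nM.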

Compound 4, half-maximal inhibitory concentration: 24000 nM
Compound 4: the middle estimate sits 1.3-fold (0.10 log units) above what was measured, within the range that was stated.
By their numbers in this assay, from the lowest: compounds 3, 4 and 2 (each within the scatter of the next).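

In this assay, replacing the 3,4-dichlorophenyl group on the saturated chain carbon bound to an amine nitrogen gives a 1.2-fold higher number from compound 3 to compound 4 (0.08 log units; within the scatter), and exchanging one two-ring group for another at the same place gives a 1.7-fold lower number from compound 2 to compound 4 (0.22 log units; within the scatter). The entering group carries a hydrogen-bond donor, hydrogen-bond acceptors and a double bond outside aromatic rings, none of which the 3,4-dichlorophenyl group has, yet neither step leaves the scatter, so these three groups cannot be told apart on this read-out. No measurement at hand accounts for this result.

The compounds shown leave open whether any group at this place can move the number beyond the scatter. A carboxylic acid or a simple alkyl chain in place of these aromatic groups would test this.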